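The source may hold more compounds than are shown below. What is called first, only, known or untested is meant among the compounds shown, and "the series" means these compounds.

Going by the values given here, compound 2 `O=C(CSc1nc(Nc2ccccc2)c2ccccc2n1)Nc1cccc([N+](=O)[O-])c1` gives 33000 nM in a functional assay on MDA-MB-231 cells (Homo sapiens) for inhibition, read by MTT assay, with a stated time of 72 h (a lower number here means a stronger inhibitor, a higher number a weaker inhibitor), the highest of the two numbers so far, although its nearest neighbour, compound 1 `O=C(CSc1nc(Nc2ccccc2)c2ccccc2n1)Nc1ccccc1Cl`, gives 24400 nM, and the step of a 1.4-fold higher number from compound 1 to compound 2 (0.13 log units; within the scatter) lies within the scatter. Compound 3 `O=C(CSc1nc(Nc2ccccc2)c2ccccc2n1)Nc1ccc(Br)cc1` differs from compound 2 by 4-bromophenyl in place of 3-nitrophenyl on an amide-type nitrogen. Among the compounds with values here, one measured step bears on this position: a 1.4-fold higher number from compound 1 to compound 2 (0.13 log units; within the scatter), which exchanged 2-chlorophenyl for 3-nitrophenyl on the amide-type nitrogen and stayed within the scatter. Both measured compounds sit at a similar level, so another exchange of the ring on this nitrogen is expected to move the number little, if at all. For compound 3 the expected step is a 1.2-fold lower number from compound 2 to compound 3 (0.07 log units; within the scatter), essentially none beyond the scatter. The estimate for compound 3 in this assay is 28000 nM, with an expected range from 10000 nM to 80000 nM.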

Compound 3, half-maximal inhibitory concentration: 11500 nM
Estimate against measurement, compound 3: 2.4-fold (0.39 log units) above; the range from low to high includes it.
By their numbers in this assay, from the lowest: compound 3; then compounds 1 and 2 (each within the scatter of the next).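

The ring on the amide-type nitrogen can move the number in this assay after all: the change to 4-bromophenyl gives a 2.9-fold lower number from compound 2 to compound 3 (0.46 log units; beyond the scatter) and a 2.1-fold lower number from compound 1 to compound 3 (0.33 log units; beyond the scatter). Both steps are modest but beyond the scatter, whereas the exchange between the two earlier rings stayed within it. Compound 3 therefore has the lowest number of the three, though no measurement shown here explains why this ring differs from the other two.

Compound 1 and compound 3 carry different halogens at different places on the ring, so the compounds shown do not separate the effect of the bromine from that of its place. From the compounds shown here alone, how this nitrogen would respond to a ring bearing an amine or a carboxylic acid, or to a plain alkyl chain instead of a ring, also remains open.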